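What Happens When Compound 2 Loses Its Fluoro?

The source may hold more compounds than are shown below. What is called first, only, known or untested is meant among the compounds shown, and "the series" means these compounds.

Of the compounds shown here, three sharing one core have been measured in an in vitro ADME assay on microsomes from liver (Mus musculus) for metabolic stability; a higher number here means that the compound lasts longer, a lower number that the compound disappears faster. Compound 1 `O=[N+]([O-])c1ccc(C2=NOC(c3ccc(N4CCCCC4)cc3)C2)o1` gives 0.78 h. Compound 2 `O=C1COCCN1c1ccc(C2CC(c3ccc([N+](=O)[O-])o3)=NO2)cc1F` gives 1.38 h, and these two values lie within the scatter of each other, so they cannot be ranked. Among the measured compounds shown here, compound 3 `CN1CCN(c2ccc(C3CC(c4ccc([N+](=O)[O-])o4)=NO3)cc2F)C(=O)C1` gives 0.62 h, and only this compound stands clearly apart from compound 2.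

The next compound is compound 4 `O=C1COCCN1c1ccc(C2CC(c3ccc([N+](=O)[O-])o3)=NO2)cc1`, which has hydrogen in place of fluoro on an aromatic carbon. That carbon is ortho to a 3-oxomorpholin-4-yl group. For the measured compounds named here, no measured pair shows this change alone, so any forecast is uncertain.

The nearest guide is a 2.2-fold lower number from compound 2 to compound 3 (0.35 log units; beyond the scatter). That modest step came from putting 4-methyl-2-oxopiperazin-1-yl in place of 3-oxomorpholin-4-yl, an exchange of a whole group, whereas compound 4 differs from compound 2 by a single fluoro. A smaller step is therefore expected in this assay, with no clear direction and nothing beyond the scatter. The estimated change is a 1.2-fold lower number from compound 2 to compound 4 (0.06 log units; within the scatter). For compound 4 the expected half-life is 1.2 h, with an estimated range of 0.65 h to 2.2 h.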

Compound 4, half-life: 1.4 h
Beside the measured number, compound 4's estimate is 1.2-fold (0.07 log units) below it; measured number inside the range.
By their numbers in this assay, from the lowest: compounds 3, 1, 2 and 4 (each within the scatter of the next, the first and the last beyond it).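

In this assay, taking away the fluoro gives a 1.0-fold higher number from compound 2 to compound 4 (0.01 log units; within the scatter) and so leaves compound 2 and compound 4 impossible to tell apart; on an aromatic carbon ortho to a 3-oxomorpholin-4-yl group, fluoro and hydrogen therefore give half-lives within the usual scatter of each other. Among the compounds shown here, with the fluoro gone, the 3-oxomorpholin-4-yl group can also be set against piperidin-1-yl as a single exchange, which the earlier compounds did not allow, and this gives a 1.8-fold higher number from compound 1 to compound 4 (0.25 log units; within the scatter) and again does not separate the two compounds. Nothing available here explains why either pair sits so close together.

Going by these compounds, only hydrogen and fluoro have been seen at this carbon, so it remains open whether a chlorine atom, a methoxy group or a nitrile there would also leave the half-life within the scatter. On these data alone, it also remains open whether hydrogen in place of fluoro would be as uneventful beside the 4-methyl-2-oxopiperazin-1-yl group of compound 3, since the present pair covers the 3-oxomorpholin-4-yl group alone.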